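Swapping Methylsulfanyl for Piperidinyl: Tolerance on Cultured Cells

The source may report more compounds than this note shows. Statements on the series, on what has been measured and on what is new or still open speak of the compounds shown alone.

Compound 1, `O=C(/C=C/c1ccc([N+](=O)[O-])o1)c1ccc(-c2ccccc2)cc1`: 50400 nM
Compound 2, `CSc1ccc(C(=O)/C=C/c2ccc([N+](=O)[O-])o2)cc1`: 13100 nM

In an ADME assay on THP-1 cells (Homo sapiens) for cytotoxicity, read by resazurin assay, with a stated time of 72 h (a higher number here means that more compound is tolerated, a lower number that less compound is tolerated), compound 2 gives the lower of the two numbers; the step of a 3.8-fold lower number from compound 1 to compound 2 (0.59 log units; beyond the scatter) means less of compound 2 is tolerated than of compound 1. Compound 3, `O=C(/C=C/c1ccc([N+](=O)[O-])o1)c1ccc(N2CCCCC2)cc1`, is unmeasured and differs from compound 2 by piperidin-1-yl in place of methylsulfanyl on an aromatic carbon. Only a 3.8-fold lower number from compound 1 to compound 2 (0.59 log units; beyond the scatter) bears on this, and loosely: there phenyl gave way to methylsulfanyl and the number fell, so returning a larger group may raise it. A modest rise is expected, a 1.9-fold higher number from compound 2 to compound 3 (0.28 log units; within the scatter). For compound 3 the estimated value is 25000 nM, between 8000 nM and 70000 nM.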

Compound 3, half-maximal cytotoxic concentration: > 50000 nM
Compound 3: no number, only a limit; the forecaster's own chance of this, stated with the estimate: 10%; at least 2.0-fold (0.30 log units) between middle value and limit.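

In this assay the group at this position, para to a large group, can lift the number as well as lower it: piperidin-1-yl in place of methylsulfanyl gives an at least 3.8-fold higher number from compound 2 to compound 3 (0.58 log units; beyond the scatter) and so more compound is tolerated. Compound 3 carries only a limit, not a number: the limit of > 50000 nM in this assay, at which 1 of the 3 values shown sits. The step from compound 1 to compound 3 therefore cannot be read.

From the compounds shown here alone, how far the true number of compound 3 lies past that limit stays open. So does whether a morpholine ring or an open-chain amine such as dimethylamino would behave like piperidin-1-yl here.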